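A few compounds are considered here, and "the series" means these few. Any claim that something is new, unique, unknown or untested is made for them only; others in the source may bear on it.

In a functional assay on NCI-H460 cells (Homo sapiens) for antiproliferative activity (on this read-out higher numbers stand for weaker inhibition and lower numbers for stronger inhibition), compound 1 `COc1ccc(S(=O)(=O)Oc2ccccc2NC(=O)c2ccccc2)cc1` gives 410 nM, and compound 2 `COc1ccc(S(=O)(=O)Oc2ccccc2NC(=O)c2ccncc2)cc1` gives 55 nM, the lowest of the two numbers seen; the step of a 7.5-fold lower number from compound 1 to compound 2 (0.87 log units; beyond the scatter) lies beyond the scatter. Compound 3 `COc1ccc(S(=O)(=O)Oc2ccccc2NC(=O)Oc2ccccc2)cc1` is not yet measured. Its difference from compound 2 is phenoxy in place of pyridin-4-yl on a carbonyl carbon. Going by the values given here, the only step that bears on this change is the one from compound 1 to compound 2, where pyridin-4-yl lowered the number; its removal in compound 3 is therefore expected to raise the number again, by a 6.4-fold higher number from compound 2 to compound 3 (0.80 log units; beyond the scatter). Compound 3 is estimated at 350 nM, within 100 nM to 1500 nM.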

Compound 3, half-maximal inhibitory concentration: > 10000 nM
Compound 3 was reported as a limit; the forecaster's own chance of this, stated with the estimate: 3%; at least 28-fold (1.45 log units) between middle value and limit.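

In this assay, compound 3 gives > 10000 nM, which is a limit of the assay and not a number. Phenoxy on this carbonyl carbon costs far more than the pyridin-4-yl comparison suggested, with an at least 180-fold higher number from compound 2 to compound 3 (2.25 log units; beyond the scatter). The loss of the ring nitrogen alone does not explain this, since the carbon-only ring of phenoxy also falls well short of phenyl, with an at least 24-fold higher number from compound 1 to compound 3 (1.38 log units; beyond the scatter).

From the compounds shown here alone, it remains open whether the oxygen itself or the added atom carries this loss. A benzyl or anilino group on the same carbonyl carbon would separate the two.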